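Trimming one methyl from the anilide of compound 3

The compounds below may be only part of what the source reports. "The series", "measured", "known", "first", "only" and "open" are said of these compounds alone.

Going by the values given here, in a functional assay on Molt4/C8 cells (Homo sapiens) for cytotoxicity (a lower number here means a stronger inhibitor, a higher number a weaker inhibitor), compound 3 `Cc1ccc(NC(=O)/C=C/C(=O)N2C/C(=C\c3ccc([N+](=O)[O-])cc3)C(=O)/C(=C/c3ccc([N+](=O)[O-])cc3)C2)cc1C` gives 660 nM, the second highest of the three numbers known; compound 1 `O=C(/C=C/C(=O)N1C/C(=C\c2ccc([N+](=O)[O-])cc2)C(=O)/C(=C/c2ccc([N+](=O)[O-])cc2)C1)Nc1ccc([N+](=O)[O-])cc1` gives 430 nM and compound 2 `O=C(/C=C/C(=O)N1C/C(=C\c2ccc([N+](=O)[O-])cc2)C(=O)/C(=C/c2ccc([N+](=O)[O-])cc2)C1)Nc1ccc(Cl)cc1` gives 1200 nM. Compound 4 `Cc1ccc(NC(=O)/C=C/C(=O)N2C/C(=C\c3ccc([N+](=O)[O-])cc3)C(=O)/C(=C/c3ccc([N+](=O)[O-])cc3)C2)cc1` differs from compound 3 by hydrogen in place of methyl on an aromatic carbon. The measured steps that alter the same part of the molecule, a 1.5-fold higher number from compound 1 to compound 3 (0.19 log units; within the scatter) and a 1.8-fold lower number from compound 2 to compound 3 (0.26 log units; within the scatter), both stayed within the scatter, whereas a 2.8-fold higher number from compound 1 to compound 2 (0.45 log units; beyond the scatter) was modest and beyond it. Among the compounds with values here, no measured pair removes a single methyl, so only a small step in this assay is expected, with no clear direction. Compound 4 is therefore estimated to give 700 nM, between 350 nM and 1400 nM. The expected step is a 1.1-fold higher number from compound 3 to compound 4 (0.03 log units; within the scatter), within the scatter.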

Compound 4, half-maximal inhibitory concentration: 700 nM
Compound 4: middle estimate and measured number agree at the digits printed; the measured number falls inside the stated range.
By their numbers in this assay, from the lowest: compounds 1, 3, 4 and 2 (each within the scatter of the next, the first and the last beyond it).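

Going from 3,4-dimethylphenyl to 4-methylphenyl on the anilide in this assay gives (a 1.1-fold higher number from compound 3 to compound 4 (0.03 log units; within the scatter)), so this one methyl can go without a difference beyond the scatter. Methyl in place of chloro (a 1.7-fold lower number from compound 2 to compound 4 (0.23 log units; within the scatter)) and methyl in place of nitro (a 1.6-fold higher number from compound 1 to compound 4 (0.21 log units; within the scatter)) also stay within the scatter, so the 4-methylphenyl anilide cannot be separated from either of those anilides. Nothing available explains these numbers. Still open, from the compounds shown here alone, is whether an amine or a carboxylic acid on this ring would move the number beyond the scatter.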